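Three Limits and the Fourth Compound Still to Be Measured

The source may hold more compounds than are shown below. What is called first, only, known or untested is meant among the compounds shown, and "the series" means these compounds.

The set comprises compound 1 `Cc1nnc(SCc2cc(=O)c3cc(Cl)ccc3o2)o1`, compound 2 `Nc1nnc(SCc2cc(=O)c3cc(Cl)ccc3o2)s1`, compound 3 `Cc1ccc2oc(CSc3nnc(N)s3)cc(=O)c2c1` and the unmeasured compound 4 `Cc1ccc2oc(CSc3nnc(C)o3)cc(=O)c2c1`. In a functional assay on SW480 cells (Homo sapiens) for cytotoxicity, read by MTT assay, with a stated time of 72 h (a higher number here means a weaker inhibitor, a lower number a stronger inhibitor), compound 1 reaches only a limit, > 25000 nM. Compound 2 likewise gives a limit in this assay, > 25000 nM. Compound 3 also gives a limit in this assay, > 25000 nM. The change from compound 2 to compound 1, (5-methyl-1,3,4-oxadiazol-2-yl in place of 5-amino-1,3,4-thiadiazol-2-yl on a sulfur), yields a step that the two limits leave unreadable from compound 2 to compound 1; the core difference methyl in place of chloro on an aromatic carbon yields a step that the two limits leave unreadable from compound 2 to compound 3. Both rest on (the limit of > 25000 nM in this assay, at which 3 of the 3 values shown sit). Compound 4 arises from compound 3 by the same change, (5-methyl-1,3,4-oxadiazol-2-yl in place of 5-amino-1,3,4-thiadiazol-2-yl on a sulfur), described at a place worded identically. Compound 3 stands at a limit, > 25000 nM. The step is expected to be a step that the limit leaves unreadable from compound 3 to compound 4. Compound 4 is estimated at 30000 nM, with a range from 15000 nM to 100000 nM.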

Compound 4, half-maximal inhibitory concentration: > 25000 nM
Compound 4 was reported as a limit; the forecaster's own chance of this, stated with the estimate: 85%; the middle value is on the limit's open side.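

Compound 1, compound 3 and compound 4 all stand at limits in this assay, so no new step can be read between compound 3 and compound 4 or between compound 1 and compound 4. The compounds shown leave open whether either change alters potency at all, as none of them yields a number.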